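Formyl in place of 3-methylbut-2-en-1-yl: series notes

The source may report more compounds than this note shows. Statements on the series, on what has been measured and on what is new or still open speak of the compounds shown alone.

In a toxicity assay on CCRF-CEM cells (Homo sapiens) for cytotoxicity (on this read-out lower numbers stand for higher toxicity in this test and higher numbers for lower toxicity in this test), compound 3 `CC(C)=CCc1cccc2c1nc(-c1c(F)cccc1F)n2Cc1c(F)cccc1F` gives 28.3 uM. Compound 1 `Fc1cccc(F)c1Cn1c(-c2c(F)cccc2F)nc2c(Br)cccc21` gives 24.5 uM. The change of group here is a 1.2-fold higher number from compound 1 to compound 3 (0.06 log units; within the scatter), within the scatter, so these two values carry no order. Compound 2 `CN(C)c1cccc2c1nc(-c1c(F)cccc1F)n2Cc1c(F)cccc1F` reports only a limit, > 100 uM. The two steps that touch this limit are an at least 4.0-fold higher number from compound 1 to compound 2 (0.61 log units; beyond the scatter) and an at least 3.5-fold lower number from compound 2 to compound 3 (0.54 log units; beyond the scatter), both beyond the scatter.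

Compound 4 `O=Cc1cccc2c1nc(-c1c(F)cccc1F)n2Cc1c(F)cccc1F` carries formyl in place of 3-methylbut-2-en-1-yl on an aromatic carbon. Formyl has no measured precedent in this series, so the steps give only rough guidance. Two of the three groups measured on this carbon stay close (a 1.2-fold higher number from compound 1 to compound 3 (0.06 log units; within the scatter)), which argues against a large move. Dimethylamino stands apart (an at least 3.5-fold lower number from compound 2 to compound 3 (0.54 log units; beyond the scatter)), which leaves room for a higher number. The expectation is therefore a small upward change or none beyond the scatter, and the estimated step is a 1.2-fold higher number from compound 3 to compound 4 (0.09 log units; within the scatter). For compound 4 the estimate is 35 uM, with an expected range of 12 uM to 100 uM.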

Compound 4, half-maximal toxic concentration: 0.82 uM
Estimate against measurement, compound 4: 43-fold (1.63 log units) above; measured number below the stated range.
By their numbers in this assay, from the lowest: compound 4; then compounds 1 and 3 (each within the scatter of the next). At a limit, above all of these: compound 2.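

On this aromatic carbon, bromo and 3-methylbut-2-en-1-yl gave no sign of how far the read-out in this assay could move, but formyl gives a 35-fold lower number from compound 3 to compound 4 (1.54 log units; beyond the scatter) and a 30-fold lower number from compound 1 to compound 4 (1.48 log units; beyond the scatter). The position can therefore carry a large shift toward higher toxicity in this test, and the replacement of dimethylamino by formyl gives an at least 120-fold lower number from compound 2 to compound 4 (2.08 log units; beyond the scatter). The size of that last step is only a minimum, as compound 2 reports a limit and not a number: the limit of > 100 uM in this assay, at which 1 of the 4 values shown sits.

An acetyl, hydroxymethyl or carboxylic acid on this carbon would show whether the lower number follows the carbonyl or belongs to formyl alone. The reason for the shift stays open: the compounds shown give read-outs in this assay only.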